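Fluorine on the benzyl ring of a triazole-linked chalcone

The source may report more compounds than this note shows. Statements on the series, on what has been measured and on what is new or still open speak of the compounds shown alone.

Measured so far in a functional assay on A549 cells (Homo sapiens) for inhibition, read by MTT assay, with a stated time of 48 h, tested at 10 uM; on this read-out higher numbers stand for more inhibition of growth at the one concentration tested and lower numbers for less inhibition of growth:
compound 1, `O=C(/C=C/c1ccc(OCc2cn(Cc3ccccc3)nn2)cc1)c1ccc(Br)cc1`, gives 34%;
compound 2, `COc1ccc(C(=O)/C=C/c2ccc(OCc3cn(Cc4ccccc4)nn3)cc2)cc1`, gives 44%;
compound 3, `O=C(/C=C/c1ccc(OCc2cn(Cc3ccccc3)nn2)cc1)c1ccc([N+](=O)[O-])cc1`, is reported as "not active" (no number reported).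

Compound 3 thus stands without a number: it carries a nitro group where compound 1 carries bromo and compound 2 carries methoxy, and it is recorded only as inactive. Among the compounds with values here, the one step between measured compounds, a number 10 percentage points higher from compound 1 to compound 2 (within the scatter), sits on the aryl ketone ring and lies within the scatter, so it says nothing about the benzyl ring.

Compound 4, `O=C(/C=C/c1ccc(OCc2cn(Cc3cccc(F)c3)nn2)cc1)c1ccc([N+](=O)[O-])cc1`, differs from compound 3 by fluoro in place of hydrogen on an aromatic carbon. Within the data shown here, no measured step touches this part of the shared core, and no step at all is large; there is therefore no ground to expect compound 4 to move beyond the scatter in this assay from where compound 3 stands. Compound 4 is expected to give only modest growth inhibition, around 12%, with a range from 0% to 35%.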

Compound 4, percent growth inhibition at one concentration: 33%
Compound 4: middle estimate off by 21 percentage points, on the low side, and the stated range covers the measured number.
By their numbers in this assay, from the lowest: compounds 4, 1 and 2 (each within the scatter of the next, the first and the last beyond it).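

In this assay, within the data shown here, compound 3 carries only the entry "not active" (no number reported) while compound 4 gives 33%, so no step between them can be read. The compounds shown leave open whether benzyl to 3-fluorobenzyl alters growth inhibition at all. No evidence at hand bears on this result.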